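This account rests on a few compounds, and the source may have more. Where it says the series, first, only, none or still open, it means among the compounds named here.

Compound 2, `Cc1ccc(CNC(=O)C(C)c2ccc(NS(C)(=O)=O)c(F)c2)cc1`, is the weaker of the two compounds measured here. In an assay on CHO cells for displacement of a labelled ligand from transient receptor potential cation channel subfamily V member 1 (Rattus norvegicus) (a lower number here means a stronger inhibitor, a higher number a weaker inhibitor), compound 2 gives 3100 nM, whereas compound 1, `CC(NC(=O)/C=C/c1ccc(C(C)(C)C)cc1)c1ccc(NS(C)(=O)=O)c(F)c1`, gives 105 nM in this assay. For the measured compounds named here, these two compounds differ in more than one place, so their values tell only that compound 1 holds the far lower number.

Compound 3, `CC(C(=O)NCc1ccc(C2CCCC2)cc1)c1ccc(NS(C)(=O)=O)c(F)c1`, has not yet been measured. It differs from compound 2 by the change (cyclopentyl in place of methyl on an aromatic carbon), a cyclopentyl in place of methyl on an aromatic carbon. Going by the values given here, no measured pair shows this change directly, so there is no step to lean on. Judged from the range spanned by compound 1 and compound 2 in this assay, a step downward beyond the scatter is expected, and the expected step of a 6.9-fold lower number from compound 2 to compound 3 (0.84 log units; beyond the scatter) is a clear one. For compound 3 the estimate in this assay is 450 nM, expected to lie between 120 nM and 1700 nM.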

Compound 3, inhibition constant: 93 nM
Beside the measured number, compound 3's estimate is 4.8-fold (0.68 log units) above it; the whole stated range lies above it.
By their numbers in this assay, from the lowest: compounds 3 and 1 (each within the scatter of the next); then compound 2.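

In this assay, for the compounds shown here, replacing methyl with cyclopentyl on this aromatic carbon, para to a large group, gives a 33-fold lower number from compound 2 to compound 3 (1.52 log units; beyond the scatter) and is the first single change that can be read in this set. It shows that the value responds strongly to the group at this position, even though the entering cyclopentyl adds no hydrogen-bond donor, no hydrogen-bond acceptor and no net charge. Nothing available accounts for the size of this step.

The compounds shown leave open whether the ring itself matters or only the added carbons, which an isopropyl, a cyclohexyl or a longer alkyl chain at this position could help to separate. They also leave open how an amine or a carboxylic acid on this carbon would compare.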